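The source may report more compounds than this note shows. Statements on the series, on what has been measured and on what is new or still open speak of the compounds shown alone.

Measured in an assay on HL-60 cells for agonist activity at N-formyl peptide receptor 3 (Homo sapiens), read by calcium flux; a lower number here means that less compound is needed, a higher number that more compound is needed for the effect:
compound 1, `Cc1cc(Cc2cccc(Cl)c2)c(=O)n(CC(=O)Nc2ccc(Br)cc2)n1`: > 50000 nM
compound 2, `COc1cc(Cc2cc(C)nn(CC(=O)Nc3ccc(I)cc3)c2=O)cc(OC)c1`: > 50000 nM
compound 3, `Cc1cc(Cc2cccc(Cl)c2)c(=O)n(CC(=O)Nc2ccc(I)cc2)n1`: > 50000 nM

The value of compound 1 in this assay is a limit of the assay, not a number. The value of compound 2 in this assay is likewise a limit. The value of compound 3 in this assay is also a limit, so compound 3 cannot be placed against the other two; all three sit at the same point, (the limit of > 50000 nM in this assay, at which 3 of the 3 values shown sit).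

Two steps reach compound 3. The exchange of halogen on the aniline, a step that the two limits leave unreadable from compound 1 to compound 3, is unreadable between two limits. The exchange of the benzyl substituent, a step that the two limits leave unreadable from compound 2 to compound 3, is equally unreadable.

Compound 4, `Cc1ccc(=O)n(CC(=O)Nc2ccc(I)cc2)n1`, differs from compound 3 by hydrogen in place of 3-chlorobenzyl on an aromatic carbon. Neither measured step touches this position, and neither gives a readable size, so no direction can be drawn from them. With every value in the series at the limit, compound 4 is expected to remain there too, estimated at 50000 nM (range 20000 nM to 150000 nM), which means an expected step of a number no higher from compound 3 to compound 4 (the limit leaves the size open).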

Compound 4, half-maximal effective concentration: > 50000 nM
Compound 4 ended at the assay's limit; the forecaster's own chance of this, stated with the estimate: 85%; the middle value sits exactly at the limit.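

Compound 3 and compound 4 both rest at a limit of the assay, so no new step can be read between them: the limit of > 50000 nM in this assay, at which 4 of the 4 values shown sit.

The compounds shown leave open how large the exchange of 3-chlorobenzyl for hydrogen is, and which change on the shared core, if any, would give a readable value.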